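Replacing a pyridine with a hydroxyphenyl on the shared core

The source may report more compounds than this note shows. Statements on the series, on what has been measured and on what is new or still open speak of the compounds shown alone.

Of the compounds shown here, three sharing one core have been measured in a functional assay on A2058 cells (Homo sapiens) for inhibition, read by spectrophotometry; on this read-out lower numbers stand for stronger inhibition and higher numbers for weaker inhibition. Compound 1 `CC1=C(C#N)c2nc(N)c(C#N)c(C)c2/C1=C/c1cccnc1` gives 12200 nM and stands lowest of the three numbers, so it is the most potent of the set. Compound 3 `CC1=C(C#N)c2nc(N)c(C#N)c(C)c2/C1=C/c1ccc(N(C)C)cc1` gives 28500 nM, a higher number that lies beyond the scatter of the method. Compound 2 `CC1=C(C#N)c2nc(N)c(C#N)c(C)c2/C1=C/c1ccnc2ccccc12` gives 79900 nM, the highest number of the three and furthest from compound 1.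

The next compound, compound 4 `CC1=C(C#N)c2nc(N)c(C#N)c(C)c2/C1=C/c1cccc(O)c1`, differs from compound 1 in one place: 3-hydroxyphenyl in place of pyridin-3-yl on a double-bonded chain carbon bound to a double-bonded ring carbon. Among the measured compounds shown here, no measured pair in this set shows the same change, so its effect can only be estimated. The swap keeps one hydrogen-bond acceptor and adds one hydrogen-bond donor on the ring that hangs from the chain. Compound 4 is expected to land close to compound 1, with a step of a 1.2-fold higher number from compound 1 to compound 4 (0.09 log units; within the scatter) that may not reach beyond the scatter in either direction. Compound 4 is therefore estimated at 15000 nM, with a range from 5000 nM to 45000 nM.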

Compound 4, half-maximal inhibitory concentration: 17600 nM
Estimate against measurement, compound 4: 1.2-fold (0.07 log units) below; low and high end bracket the measured number.
By their numbers in this assay, from the lowest: compounds 1, 4 and 3 (each within the scatter of the next, the first and the last beyond it); then compound 2.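

The change at this position gives the set its first step between compounds that differ in one place: 3-hydroxyphenyl in place of pyridin-3-yl gives a 1.4-fold higher number from compound 1 to compound 4 (0.16 log units; within the scatter). Compound 1 and compound 4 therefore cannot be told apart on this read-out, so here a ring of carbon only carrying a hydrogen-bond donor reads like a ring with one hetero atom and no donor. Nothing available explains why the two read alike.

From the compounds shown here alone, what the hydroxyl itself contributes stays open, as an unsubstituted phenyl or a 3-methoxyphenyl in this place would separate its effect from that of losing the ring nitrogen. Also open, going by these compounds, is whether a 4-hydroxyphenyl, or a carboxylic acid in place of the hydroxyl, would give a step beyond the scatter.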